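This account rests on a few compounds, and the source may have more. Where it says the series, first, only, none or still open, it means among the compounds named here.

Compound 1 `FC(F)(F)c1ccc(Nc2cc3[nH]c(-c4cccc(C(F)(F)F)c4)nc3cn2)nc1`: in an ADME assay on microsomes from liver (Homo sapiens) for metabolic stability, read by LC-MS, with a stated time of 30 min, tested at 0.1 uM (a lower number here means that less of the compound is left, a higher number that more of the compound is left), compound 1 gives 90%.
Compound 2 `FC(F)(F)c1ccc(Nc2cc3[nH]c(C4CCOC4)nc3cn2)nc1`: in this assay compound 2 gives 81%.
Compound 3 `FC(F)(F)c1ccc(Nc2cc3[nH]c(C4CC4)nc3cn2)nc1`: in this assay compound 3 gives 97%.

Compound 3 holds the highest of the three numbers in this assay. Its nearest neighbour is compound 1, with a step of a number 7 percentage points higher from compound 1 to compound 3 (within the scatter), so these two cannot be told apart. Compound 2 is furthest away, with a step of a number 16 percentage points higher from compound 2 to compound 3 (beyond the scatter). All three substituents on this carbon of the shared core thus give numbers that sit in a fairly narrow band.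

Compound 4 `FC1(F)CC(c2nc3cnc(Nc4ccc(C(F)(F)F)cn4)cc3[nH]2)C1` differs from compound 3 in one place: 3,3-difluorocyclobutyl in place of cyclopropyl on an aromatic carbon. Among the compounds with values here, the steps that bear on this change are those that reach compound 3, namely a number 7 percentage points higher from compound 1 to compound 3 (within the scatter) and a number 16 percentage points higher from compound 2 to compound 3 (beyond the scatter); one lies within the scatter, the other is modest. Neither speaks for a large move in this assay. A small decrease from the top number of compound 3 is expected, within or just beyond the scatter, giving an estimated step of a number 9 percentage points lower from compound 3 to compound 4 (within the scatter). Compound 4 is therefore estimated at 88%, with a range from 72% to 99%.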

Compound 4, percent of the compound remaining: 88%
Compound 4: the middle estimate sits on the measured number at the digits printed; measured number inside the range.
By their numbers in this assay, from the lowest: compounds 2, 4, 1 and 3 (each within the scatter of the next, the first and the last beyond it).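

In this assay, the 3,3-difluorocyclobutyl group, a four-membered ring in place of the three-membered one on the aromatic carbon between two ring nitrogen atoms, gives a number 9 percentage points lower from compound 3 to compound 4 (within the scatter) and, set against the other two groups, a number 7 percentage points higher from compound 2 to compound 4 (within the scatter) and a number 2 percentage points lower from compound 1 to compound 4 (within the scatter) as well. All three steps stay within the scatter, so compound 4 cannot be told apart from any earlier compound, even though compound 2 and compound 3 do separate from each other. This position therefore accepts a fourth group, one with fluorine on a carbon ring, without a readable change, and nothing given here explains that result.

The compounds shown leave open how an amine or a carboxylic acid on this carbon would read in this assay and whether either would separate from these four groups. They also leave open whether a longer chain in this place would give a step beyond the scatter from compound 3.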